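This account rests on a few compounds, and the source may have more. Where it says the series, first, only, none or still open, it means among the compounds named here.

Measured compounds:
- compound 1, `CN(C(=O)CCc1ccccc1)c1ccc2[nH]c(-c3n[nH]c4ccccc34)cc2n1`: 7380 nM
- compound 2, `CN(C(=O)c1ccccc1)c1ccc2[nH]c(-c3n[nH]c4cc(C#N)ccc34)cc2n1`: 20900 nM

Of the compounds shown here, two sharing one core have been measured in a functional assay on KB cells (Homo sapiens) for antiproliferative activity, read by MTT assay, with a stated time of 72 h; a higher number here means a weaker inhibitor, a lower number a stronger inhibitor. Compound 1 gives 7380 nM, and compound 2 gives 20900 nM; compound 1 therefore stands on the lower of the two numbers, and the gap between them lies beyond the usual scatter of this kind of measurement. Going by the values given here, no pair differing in one place has been measured, so no single step size is known here.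

Compound 3, `CN(c1ccc2[nH]c(-c3n[nH]c4ccccc34)cc2n1)S(=O)(=O)c1ccc(Cl)cc1`, is a variation of compound 1 that has not yet been measured in this assay. The difference between them is

(4-chlorophenyl)sulfonyl in place of phenethylcarbonyl on a nitrogen on an aromatic ring

Among the compounds with values here, with only two measured compounds and no comparable step to lean on, the expected change from compound 1 to compound 3 in this assay is taken to be small, in no firm direction, and likely within the scatter, as a 1.1-fold higher number from compound 1 to compound 3 (0.04 log units; within the scatter) expresses. On that basis compound 3 is estimated to give 8000 nM in this assay, with a likely range from 2500 nM to 25000 nM.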

Compound 3, half-maximal inhibitory concentration: 8350 nM
For compound 3 the middle estimate is 1.0-fold (0.02 log units) below the measured one, within the range that was stated.
By their numbers in this assay, from the lowest: compounds 1 and 3 (each within the scatter of the next); then compound 2.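

In this assay, the first step measured at this place, on a nitrogen on an aromatic ring, is a 1.1-fold higher number from compound 1 to compound 3 (0.05 log units; within the scatter), so (4-chlorophenyl)sulfonyl and phenethylcarbonyl cannot be told apart here. The two groups are far from identical: a sulfonyl takes the place of a carbonyl, a chlorine appears on the six-membered aromatic ring, and the saturated chain is gone, although the heavy-atom count stays the same. This nitrogen therefore accepts both groups with numbers that stay within the scatter of each other, while nothing available explains why they read alike.

The contributions of the sulfonyl and the chlorine remain unseparated: a plain phenylsulfonyl group, or a 4-chlorophenylcarbonyl group, would be needed to read each one alone. On these data alone, how much of the group on this nitrogen matters at all also stays open, and a small acetyl group or a chain ending in an amine would test that question in this assay.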